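A few compounds are considered here, and "the series" means these few. Any claim that something is new, unique, unknown or untested is made for them only; others in the source may bear on it.

Of the compounds shown here, three from one series have so far been measured in a functional assay on WiDr cells (Homo sapiens) for inhibition, read by sulforhodamine B assay, with a stated time of 48 h; on this read-out higher numbers stand for weaker inhibition of growth and lower numbers for stronger inhibition of growth. Compound 1 `COC(=O)[C@@]1(C)CC[C@@H]2C3=C1CC[C@@H](C)[C@]3(C)C[C@@H]1c3ccccc3N[C@H]21` is the parent of the set; in this assay compound 1 gives 50000 nM. Compound 2 `COC(=O)[C@@]1(C)CC[C@@H]2C3=C1CC[C@@H](C)[C@]3(C)C[C@@H]1c3cc(C)ccc3N[C@H]21` carries a methyl on an aromatic carbon and gives 32000 nM, while compound 3 `COC(=O)[C@@]1(C)CC[C@@H]2C3=C1CC[C@@H](C)[C@]3(C)C[C@@H]1c3cc(OC)ccc3N[C@H]21` carries a methoxy at that aromatic carbon and gives 25000 nM. All three numbers sit within the usual scatter of one another, so on what is shown compound 1 is not separated from the other two.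

Compound 4 `COC(=O)[C@@]1(C)CC[C@@H]2C3=C1CC[C@@H](C)[C@]3(C)C[C@@H]1c3cccc(C)c3N[C@H]21` differs from compound 1 by methyl in place of hydrogen on an aromatic carbon. The two measured steps that bear on this change are both small substitutions on the aromatic ring: a 1.6-fold lower number from compound 1 to compound 2 (0.19 log units; within the scatter) and a 2.0-fold lower number from compound 1 to compound 3 (0.30 log units; within the scatter). The comparison a 1.3-fold lower number from compound 2 to compound 3 (0.11 log units; within the scatter) adds that swapping one small group for another at that ring also stayed within the scatter. Nothing measured here suggests that a methyl placed on a different aromatic carbon should behave otherwise. The expectation is therefore a step from compound 1 to compound 4 of no more than the scatter, estimated as a 1.3-fold lower number from compound 1 to compound 4 (0.12 log units; within the scatter). For compound 4 the estimated value in this assay is 38000 nM, expected to fall between 15000 nM and 90000 nM.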

Compound 4, concentration for 50% growth inhibition: 43000 nM
The estimate for compound 4 lay 1.1-fold (0.05 log units) below the measured number; low and high end bracket the measured number.
By their numbers in this assay, from the lowest: compounds 3, 2, 4 and 1 (each within the scatter of the next).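

In this assay, methyl in place of hydrogen on this aromatic carbon, which is ortho to a fused ring and meta to a fused ring, gives a 1.2-fold lower number from compound 1 to compound 4 (0.07 log units; within the scatter). The earlier compounds shown here showed a methyl on only one aromatic carbon, in a 1.6-fold lower number from compound 1 to compound 2 (0.19 log units; within the scatter), so this result adds a second carbon of the same ring where the change leaves the number within the scatter of the parent. The step therefore gives no sign that this position matters for growth inhibition in these cells, although a change too small to rise above the scatter cannot be ruled out, and no supporting measurement is available to explain the result.

The compounds shown leave open whether a different kind of group on this carbon, such as an amine, a carboxylic acid or a longer chain, would move the number beyond the scatter. They also leave open whether a methoxy here would behave as the methyl does, since this position has so far been shown with only hydrogen and methyl.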